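Adding a methyl group to the core of compound 2

The compounds below may be only part of what the source reports. "The series", "measured", "known", "first", "only" and "open" are said of these compounds alone.

For the measured compounds named here, in a functional assay on HeLa cells (Homo sapiens) for inhibition, read by sulforhodamine B assay, with a stated time of 48 h (on this read-out higher numbers stand for weaker inhibition of growth and lower numbers for stronger inhibition of growth), compound 2 `c1ccc(-c2nc3ncccn3c2CN2CCCC2)cc1` gives 70 nM and holds the lower of the two numbers measured so far. Compound 1 `Cc1ccn2c(CN3CCCC3)c(-c3ccc(O)cc3)nc2n1` gives 4760 nM in this assay and stands beyond the scatter from compound 2. Compound 3 `Cc1ccn2c(CN3CCCC3)c(-c3ccccc3)nc2n1` comes from compound 2 by one change: methyl in place of hydrogen on an aromatic carbon. Going by the values given here, no measured pair differs in one place only, so this change has no direct precedent in this assay here. Compound 1 also carries the methyl but differs from compound 2 elsewhere too, so the value of compound 1 at 4760 nM is only a loose hint of a rise. The expected change is a 3.6-fold higher number from compound 2 to compound 3 (0.55 log units; beyond the scatter) toward weaker inhibition of growth, though a result within the scatter remains possible. Compound 3 is expected at 250 nM within 50 nM to 1300 nM on this estimate.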

Compound 3, concentration for 50% growth inhibition: 180 nM
Beside the measured number, compound 3's estimate is 1.4-fold (0.14 log units) above it; measured number inside the range.
By their numbers in this assay, from the lowest: compound 2; then compound 3; then compound 1.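

In this assay the methyl on an aromatic carbon of the six-membered aromatic ring with 2 nitrogen gives a 2.6-fold higher number from compound 2 to compound 3 (0.41 log units; beyond the scatter) and so costs only a modest part of the growth inhibition at this position. With the methyl present on both compounds, hydrogen in place of hydroxy on an aromatic carbon gives a 26-fold lower number from compound 1 to compound 3 (1.42 log units; beyond the scatter) and this far larger step shows that the high number of compound 1 goes mainly with the hydroxy and not with the methyl. No measurement shown here explains either step.

From the compounds shown here alone, at this position only hydrogen and methyl can be compared, so the effect of an ethyl group, a methoxy group or a chlorine atom there stays open. Going by these compounds, it is also open whether the hydroxy would cost as much in a compound without the methyl, and how an amine at that same carbon would compare.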